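This account rests on a few compounds, and the source may have more. Where it says the series, first, only, none or still open, it means among the compounds named here.

Series notes. Compound 1 `CC(C)(O)Cn1nc(-c2cc(C3CC3)on2)c2c(N)ncnc21` and compound 2 `CCCCCCCn1nc(-c2cc(C3CC3)on2)c2c(N)ncnc21` share a core and differ only in the group on the ring nitrogen. Going by the values given here, in an assay on isolated protein for inhibition of proto-oncogene tyrosine-protein kinase receptor Ret variant V804M (Homo sapiens), read by radiometric assay and 33P incorporation, in the presence of a further agent that is not named here (a lower number here means a stronger inhibitor, a higher number a weaker inhibitor), compound 1 gives 217 nM, and in the same assay compound 2 gives 927 nM, the highest of the two numbers so far; the only step, hexyl in place of 1-hydroxy-1-methylethyl on a saturated chain carbon bound to an aromatic nitrogen, runs a 4.3-fold higher number from compound 1 to compound 2 (0.63 log units; beyond the scatter). Compound 3 `Nc1ncnc2c1c(-c1cc(C3CC3)on1)nn2C1CCOCC1` is not yet measured. The change from compound 2 is oxan-4-yl in place of heptyl on an aromatic nitrogen: the heptyl with no hydrogen-bond acceptor gives way to a ring bearing one oxygen acceptor. Among the compounds with values here, the single measured step bears on it only indirectly, since it shows that removing the oxygen-bearing group from compound 1 made the number higher. Returning an oxygen acceptor to that position is therefore expected to lower the number again, to a step of about a 3.1-fold lower number from compound 2 to compound 3 (0.49 log units; beyond the scatter). The estimate for compound 3 in this assay is 300 nM, range 120 nM to 800 nM.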

Compound 3, half-maximal inhibitory concentration: 41 nM
Compound 3: middle estimate off by 7.3-fold (0.86 log units), on the high side; the whole stated range lies above it.
By their numbers in this assay, from the lowest: compound 3; then compound 1; then compound 2.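

In this assay the change to oxan-4-yl runs a 23-fold lower number from compound 2 to compound 3 (1.35 log units; beyond the scatter) and also a 5.3-fold lower number from compound 1 to compound 3 (0.72 log units; beyond the scatter) and so goes past the level of the oxygen-bearing chain of compound 1 rather than merely back to it. The position therefore accepts a six-membered non-aromatic ring on the aromatic nitrogen, and the hydroxy group of compound 1 is not needed for the lowest number in the series, since the oxan-4-yl carries no hydrogen-bond donors. No measurement at hand speaks to why the number falls with this change.

Open, going by these compounds, is how much of the step belongs to the ring and how much to its oxygen, which cyclohexyl, the all-carbon ring, would separate. Also open, on these data alone, is whether a ring amine such as piperidin-4-yl fits this position as well as oxan-4-yl.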